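This account rests on a few compounds, and the source may have more. Where it says the series, first, only, none or still open, it means among the compounds named here.

In an assay on isolated protein for inhibition of thyroid hormone receptor beta (Homo sapiens), read by fluorescence polarization (a higher number here means a weaker inhibitor, a lower number a stronger inhibitor), compound 1 `CS(=O)(=O)c1ccc(C(=O)NCCCC(=O)N2CCCCC2)cc1[N+](=O)[O-]` gives only a limit, > 60000 nM. Compound 2 `CS(=O)(=O)c1ccc(C(=O)NCCC(=O)N2CCc3ccccc32)cc1[N+](=O)[O-]` likewise gives a limit, > 60000 nM. Compound 3 `CS(=O)(=O)c1ccc(C(=O)NCCC(=O)N2CCc3ccccc3C2)cc1[N+](=O)[O-]` also gives a limit, > 60000 nM. Compound 3 thus stands where every value shown stands, at the limit of > 60000 nM in this assay, at which 3 of the 3 values shown sit. Among the compounds with values here, the one measured step in this assay, a step that the two limits leave unreadable from compound 2 to compound 3, is therefore unreadable in size. Compound 4 `CS(=O)(=O)c1ccc(C(=O)NCCC(=O)N2CCCCC2)cc1[N+](=O)[O-]` differs from compound 3 in one place: piperidin-1-yl in place of 1,2,3,4-tetrahydroisoquinolin-2-yl on a carbonyl carbon. Within the data shown here, no measured step resembles this exchange, and the only step at hand gives no readable size, so no step beyond the scatter can be predicted. The step of a number no higher from compound 3 to compound 4 (the limit leaves the size open) is expected to be none that the assay can read. Compound 4 is estimated at 60000 nM, between 20000 nM and 200000 nM, most likely again only a limit.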

Compound 4, half-maximal inhibitory concentration: > 60000 nM
Compound 4 ended at the assay's limit; the forecaster's own chance of this, stated with the estimate: 90%; the middle value sits exactly at the limit.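

In this assay compound 4 gives only a limit, > 60000 nM, so its steps from compound 1, compound 2 and compound 3 cannot be read. The compounds shown leave open which, if any, of these exchanges changes inhibition.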